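This account rests on a few compounds, and the source may have more. Where it says the series, first, only, none or still open, it means among the compounds named here.

Compound 1, `Cc1nc(NCCNS(C)(=O)=O)nc2ccc(NC(=O)/C=C/c3ccc(OC(F)(F)F)cc3)cc12`: 169 nM
Compound 2, `Cc1nc(N2CCC(N3CCCC3=O)CC2)nc2ccc(NC(=O)/C=C/c3ccc(Cl)cc3)cc12`: 74 nM
Compound 3, `COc1ccc(/C=C/C(=O)Nc2ccc3nc(N4CCC(O)(C5CC5)CC4)nc(C)c3c2)cc1`: 116 nM

All three share a core and were tested in an assay on CHO-K1 cells for displacement of a labelled ligand from melanin-concentrating hormone receptor 1 (Homo sapiens), read by scintillation proximity assay, with a stated time of 2 h; a lower number here means a stronger inhibitor, a higher number a weaker inhibitor. Compound 1 shows the highest number of the three. Its gap to compound 3 lies within the scatter of repeated measurements, so those two cannot be ordered, whereas compound 2 sits beyond the scatter with the lower number. Going by the values given here, compounds 2 and 3 each carry a piperidine-based group on the core where compound 1 has an open chain, but they also differ from compound 1 in the group on the other aromatic ring, so no pair of measured compounds isolates either change on its own.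

Compound 4, `Cc1nc(N2CCC(N3CCNC3=O)CC2)nc2ccc(NC(=O)/C=C/c3ccc(OC(F)(F)F)cc3)cc12`, has not yet been measured. It keeps the trifluoromethoxy-bearing ring of compound 1 and differs from it only at the core: 4-(2-oxoimidazolidin-1-yl)piperidin-1-yl in place of (2-(methanesulfonamido)ethyl)amino on an aromatic carbon. The entering group resembles the piperidine-based groups of compound 2, which gives 74 nM, and compound 3, which gives 116 nM. On that basis a moderate step toward a lower number is expected from compound 1 to compound 4, a 2.1-fold lower number from compound 1 to compound 4 (0.32 log units; beyond the scatter), likely beyond the scatter. Compound 4 is estimated at 80 nM, with a range from 30 nM to 220 nM.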

Compound 4, half-maximal inhibitory concentration: 66 nM
Beside the measured number, compound 4's estimate is 1.2-fold (0.08 log units) above it; the range from low to high includes it.
By their numbers in this assay, from the lowest: compounds 4, 2, 3 and 1 (each within the scatter of the next, the first and the last beyond it).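

In this assay, putting 4-(2-oxoimidazolidin-1-yl)piperidin-1-yl in place of (2-(methanesulfonamido)ethyl)amino on the aromatic carbon between two ring nitrogen atoms gives a 2.6-fold lower number from compound 1 to compound 4 (0.41 log units; beyond the scatter) while the trifluoromethoxy-bearing ring stays the same. Going by these compounds alone, this is the first pair that differs in one place only, so a change at this position can now be read on its own, without a change on the other aromatic ring mixed into it, and it shows that a group with two non-aromatic rings can stand here in place of an open chain with no loss of binding. Nothing measured here explains the step, so it cannot be said whether it comes from the piperidine, from the ring attached to it or from the loss of the methanesulfonamido group.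

A piperidine carrying a plain amine or a carboxylic acid instead of the 2-oxoimidazolidin-1-yl ring would help separate those parts, and a longer chain ending in the same methanesulfonamido group would test the open-chain side. As far as these compounds go, whether the step holds with a chloro or methoxy group on the other aromatic ring also remains open.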